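Benzyloxyphenyl series: chlorine for methyl on the benzyl ring

The source may report more compounds than this note shows. Statements on the series, on what has been measured and on what is new or still open speak of the compounds shown alone.

In an assay for inhibition of Amine oxidase [flavin-containing] A (Rattus norvegicus) (a higher number here means a weaker inhibitor, a lower number a stronger inhibitor), compound 2 `Cc1cccc(COc2ccc(-c3nn(CCC#N)c(=S)o3)cc2)c1` gives 14000 nM. Compound 1 `Cc1ccc(COc2ccc(-c3nn(CCC#N)c(=O)o3)cc2)cc1` gives 25000 nM in this assay, and the two values lie within the scatter of each other, so no ordering between them is claimed. Compound 3 `N#CCCn1nc(-c2ccc(OCc3ccc(Cl)cc3)cc2)oc1=S` differs from compound 2 by 4-chlorophenyl in place of 3-methylphenyl on a saturated chain carbon bound to an oxygen on an aromatic ring. Going by the values given here, no measured pair in the set shows this change, so the size of the step is unknown; the expectation is a step of no more than the scatter, in either direction, a 1.2-fold lower number from compound 2 to compound 3 (0.07 log units; within the scatter). Compound 3 is therefore estimated at 12000 nM, with a range from 4000 nM to 40000 nM.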

Compound 3, half-maximal inhibitory concentration: 2700 nM
Compound 3: the middle estimate sits 4.4-fold (0.65 log units) above what was measured, outside the stated range (below it).
By their numbers in this assay, from the lowest: compound 3; then compounds 2 and 1 (each within the scatter of the next).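

Going by these compounds alone, at this position, on a saturated chain carbon bound to an oxygen on an aromatic ring, the choice of benzyl ring matters in this assay: 4-chlorophenyl in place of 3-methylphenyl gives a 5.2-fold lower number from compound 2 to compound 3 (0.71 log units; beyond the scatter), the only step read so far. The substituent and its place on the ring change together, so this step cannot be assigned to either alone. No available data explain the step.

Still open, on these data alone, is what a bromine, a methoxy group or an unsubstituted benzyl would give here.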